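The source may hold more compounds than are shown below. What is called first, only, known or untested is meant among the compounds shown, and "the series" means these compounds.

In a functional assay on K562 cells (Homo sapiens) for cytotoxicity, read by propidium iodide staining, with a stated time of 48 h (on this read-out higher numbers stand for lower toxicity in this test and lower numbers for higher toxicity in this test), compound 1 (`O=C(CN1C(=O)S/C(=C/c2ccco2)C1=O)Nc1ccc(Br)cc1`) gives 94000 nM. Compound 3 (`Cc1cccc2sc(NC(=O)CN3C(=O)S/C(=C/c4ccco4)C3=O)nc12`) gives 97100 nM, and these two numbers lie within the usual scatter of each other. Compound 2 (`O=C(CN1C(=O)S/C(=C/c2ccco2)C1=O)Nc1ccc(Cl)cc1C(F)(F)F`) has no exact number, only a limit of the assay, > 100000 nM.

The next compound to be tested is compound 4 (`Cc1cc(NC(=O)CN2C(=O)S/C(=C/c3ccco3)C2=O)no1`). It carries 5-methyl-1,2-oxazol-3-yl in place of 4-bromophenyl on an amide-type nitrogen, and the rest of the molecule stays the same: 5-methyl-1,2-oxazol-3-yl in place of 4-bromophenyl on an amide-type nitrogen.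

Within the data shown here, no two measured compounds differ in only one place, so the data give no direct measure of what a single change of this kind does. Among the measured compounds shown here, the only guide is how closely the measured numbers sit together, with compound 1 at 94000 nM and compound 3 at 97100 nM. On that basis, no step beyond the scatter is expected in this assay. The estimated step of a 1.0-fold higher number from compound 1 to compound 4 (0.00 log units; within the scatter) is therefore small. The expected value for compound 4 is 95000 nM, within an estimated range of 50000 nM to 170000 nM.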

Compound 4, half-maximal cytotoxic concentration: 98600 nM
The estimate for compound 4 lay 1.0-fold (0.02 log units) below the measured number; low and high end bracket the measured number.
By their numbers in this assay, from the lowest: compounds 1, 3 and 4 (each within the scatter of the next). At a limit, above all of these: compound 2.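

With a 1.0-fold higher number from compound 1 to compound 4 (0.02 log units; within the scatter), there is now a direct measure of a single change on this amide-type nitrogen. In this assay, replacing 4-bromophenyl, a six-membered aromatic ring of carbon only, with 5-methyl-1,2-oxazol-3-yl, a five-membered aromatic ring with 2 hetero atoms, leaves the number unmoved, so this read-out does not separate these two groups. Compound 2 gives only a limit, and a step this small may say little because the numbers sit close to where the assay stops: the limit of > 100000 nM in this assay, at which 1 of the 4 values shown sits.

From the compounds shown here alone, it remains open whether a non-aromatic group at this place, such as a simple amine, a carboxylic acid or a longer alkyl chain, would give a number clearly lower than these. Going by these compounds, whether a change to the shared core would do so also remains open.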